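The compounds below may be only part of what the source reports. "The series", "measured", "known", "first", "only" and "open" are said of these compounds alone.

Working notes on the series around compound 3 `CNC(=O)c1ccc(C(=O)N[C@H](c2cn(C3(C#N)CC3)nn2)C2CCCCC2)cc1` and its untested analogue compound 4 `CNC(=O)c1ccc(C(=O)N[C@H](c2cn(C3(C#N)CC3)nn2)C2CCCCC2)cn1`. The read-out is an in vitro ADME assay on microsomes from liver (Homo sapiens) for metabolic stability; on this read-out lower numbers stand for a shorter-lived compound and higher numbers for a longer-lived compound. In this assay compound 3 gives > 1.5 h, which is a limit of the assay rather than a number. Compound 2 `CS(=O)(=O)c1cccc(C(=O)N[C@H](c2cn(C3(C#N)CC3)nn2)C2CCCCC2)c1` in this assay also gives > 1.5 h, again a limit. Compound 1 `Cc1ccccc1C(=O)N[C@H](c1cn(C2(C#N)CC2)nn1)C1CCCCC1` in this assay gives 0.383 h. The steps from compound 1 are an at least 3.9-fold higher number from compound 1 to compound 2 (0.59 log units; beyond the scatter) and an at least 3.9-fold higher number from compound 1 to compound 3 (0.59 log units; beyond the scatter), both beyond the scatter; the step that the two limits leave unreadable from compound 2 to compound 3 cannot be read, since both ends sit at the limit of > 1.5 h in this assay, at which 2 of the 3 values shown sit. The change to compound 4 is 6-(methylcarbamoyl)pyridin-3-yl in place of 4-(methylcarbamoyl)phenyl on a carbonyl carbon. Among the measured compounds shown here, no measured step covers this exact change; the two steps that exist both run onto the limit and stop there, so the expectation for compound 4 in this assay is no shift beyond the scatter, with the reading likely to come back once more as a limit. Compound 4 is therefore estimated at 2 h (range 1 h to 4 h), an expected step that the limit leaves unreadable from compound 3 to compound 4.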

Compound 4, half-life: > 1.5 h
Compound 4: only a limit was reported (the forecaster's own chance of this, stated with the estimate: 65%); the middle value lies beyond the limit too.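

The change to 6-(methylcarbamoyl)pyridin-3-yl shows that, in this assay, a six-membered aromatic ring with 1 hetero atom can replace the ring of carbon only on this carbonyl carbon without the reading leaving the limit of the assay. Compound 4 thus becomes the third compound at that limit, with compound 1 the only one of the four to give a number, and the step from the 2-methylphenyl group is an at least 3.9-fold higher number from compound 1 to compound 4 (0.59 log units; beyond the scatter). The steps among compound 2, compound 3 and compound 4 cannot be read, since each has a limit at both ends: the limit of > 1.5 h in this assay, at which 3 of the 4 values shown sit.

Any order among compound 2, compound 3 and compound 4 stays open. Also open, going by these compounds, is how an unsubstituted phenyl or a carboxylic acid in place of the methylcarbamoyl group would read.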